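Changing the Phenyl Substituent: From Compound 3 to Compound 4

The source may report more compounds than this note shows. Statements on the series, on what has been measured and on what is new or still open speak of the compounds shown alone.

Of the compounds shown here, three built on one shared core have been measured in a functional assay on OVCAR-5 cells (Homo sapiens) for inhibition, read by CCK-8 assay, with a stated time of 72 h, tested at 1 uM; a higher number here means more inhibition of growth at the concentration tested, a lower number less inhibition of growth. Compound 1 `CN(C)C(=O)c1cc2cnc(Nc3ccc(NC(=O)C4(C(=O)Nc5ccc(F)cc5)CC4)cc3)nc2n1C1CCCC1` carries a 4-fluorophenyl on an amide-type nitrogen, and compound 1 gives 65.4%. Compound 2 `CN(C)C(=O)c1cc2cnc(Nc3ccc(NC(=O)C4(C(=O)Nc5cccc(O)c5)CC4)cc3)nc2n1C1CCCC1` bears a 3-hydroxyphenyl at that position, and compound 2 gives 58.5%. Compound 3 `CN(C)C(=O)c1cc2cnc(Nc3ccc(NC(=O)C4(C(=O)Nc5ccccc5F)CC4)cc3)nc2n1C1CCCC1` carries a 2-fluorophenyl there, and compound 3 gives 58%. Compound 3 thus holds the lowest of the three numbers, yet both of its neighbours sit within the scatter: a number 7.4 percentage points lower from compound 1 to compound 3 (within the scatter) and a number 0.5 percentage points lower from compound 2 to compound 3 (within the scatter). The remaining step, a number 6.9 percentage points lower from compound 1 to compound 2 (within the scatter), is likewise within the scatter, so none of the three phenyl substituents separates itself from the others on these numbers.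

Compound 4 `CN(C)C(=O)c1cc2cnc(Nc3ccc(NC(=O)C4(C(=O)Nc5cccc(Cl)c5)CC4)cc3)nc2n1C1CCCC1` differs from compound 3 in one place: 3-chlorophenyl in place of 2-fluorophenyl on an amide-type nitrogen. Among the measured compounds shown here, no measured step exchanges a 2-fluorophenyl for a 3-chlorophenyl, but every measured step that alters the substitution of this phenyl ring remained within the scatter, so no step beyond the scatter is expected here either. The step of a number 2 percentage points higher from compound 3 to compound 4 (within the scatter) is therefore estimated to be small. Compound 4 is expected to give 60% in this assay, with a range from 48% to 72%.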

Compound 4, percent growth inhibition at one concentration: 15.5%
The estimate for compound 4 lay 44.5 percentage points above the measured number, outside the stated range (below it).
By their numbers in this assay, from the lowest: compound 4; then compounds 3, 2 and 1 (each within the scatter of the next).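

The phenyl ring on this amide-type nitrogen proved less forgiving than the first three compounds suggested: in this assay, 3-chlorophenyl in place of 2-fluorophenyl gave a number 42.5 percentage points lower from compound 3 to compound 4 (beyond the scatter), chloro in place of hydroxy on an aromatic carbon gave a number 43 percentage points lower from compound 2 to compound 4 (beyond the scatter), and 3-chlorophenyl in place of 4-fluorophenyl gave a number 49.9 percentage points lower from compound 1 to compound 4 (beyond the scatter). The step from the 3-hydroxyphenyl is the most telling, as it changes only the group on that aromatic carbon, so the place of substitution alone does not set the outcome: with hydroxy there, the number stays within the scatter of the two fluorophenyl compounds, and with chloro, it falls well beyond it. Nothing available explains this loss of growth inhibition.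

The compounds shown leave open whether the drop belongs to chloro at this place on the ring or to chloro anywhere on it, which 2-chlorophenyl and 4-chlorophenyl would separate. They also leave open whether 3-bromophenyl, 3-methylphenyl or 3-methoxyphenyl would follow compound 4 or stay with compound 2.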